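This account rests on a few compounds, and the source may have more. Where it says the series, first, only, none or still open, it means among the compounds named here.

Measured in a functional assay on HL-60 cells (Homo sapiens) for antiproliferative activity, read by XTT assay, with a stated time of 72 h; on this read-out higher numbers stand for weaker inhibition and lower numbers for stronger inhibition:
- Compound 1 `Cc1nc(N)c2c(-c3ccoc3)cn([C@@H]3O[C@H](CO)[C@@H](O)[C@H]3O)c2n1`: > 20000 nM, a limit of the assay
- Compound 2 `Nc1nc2c(c(-c3ccco3)cn2[C@@H]2O[C@H](CO)[C@@H](O)[C@H]2O)c(=O)[nH]1`: > 20000 nM, a limit of the assay

Neither reading is a number. The whole record so far is the limit of > 20000 nM in this assay, at which 2 of the 2 values shown sit. Compound 2, which carries a furan-2-yl group, therefore stands at a limit, and its true position in this assay is not known.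

Compound 3 `Nc1nc2c(c(-c3cccs3)cn2[C@@H]2O[C@H](CO)[C@@H](O)[C@H]2O)c(=O)[nH]1` differs from compound 2 in one place. It has thiophen-2-yl in place of furan-2-yl on an aromatic carbon of a five-membered aromatic ring with 1 nitrogen, part of a fused or bridged system of two rings (thiophen-2-yl in place of furan-2-yl on an aromatic carbon). For the measured compounds named here, no measured pair shows what such an exchange does in this assay, so no shift beyond the usual scatter is expected, although a limit leaves room for a stronger result. The estimated step of a number no higher from compound 2 to compound 3 (the limit leaves the size open) is expected to stay within that scatter. For compound 3 the expected value is 20000 nM. The estimated range for compound 3 runs from 6000 nM to 50000 nM, and the assay may well again report only a limit.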

Compound 3, half-maximal inhibitory concentration: > 20000 nM
Compound 3 gave a limit, no number (the forecaster's own chance of this, stated with the estimate: 75%); the middle value lies on the limit itself.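

In this assay compound 3 gives > 20000 nM, a limit of the assay and not a number. Compound 2 also stands at a limit, so no step can be read between compound 2 and compound 3. The compounds shown leave open where any of them truly lies in this read-out, since the whole record remains a single limit: the limit of > 20000 nM in this assay, at which 3 of the 3 values shown sit.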